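The compounds below may be only part of what the source reports. "The series", "measured", "known", "first", "only" and "open" are said of these compounds alone.

Measured so far in a functional assay for agonist activity at G protein-coupled receptor 88 (Homo sapiens), read by HTRF and cAMP accumulation; a higher number here means that more compound is needed for the effect, a lower number that less compound is needed:
- compound 1, `Cc1ccccc1-c1ccc(N(C[C@@H](N)CC(C)C)C(=O)[C@@H]2C[C@H]2c2ccccc2)cc1`, gives 3400 nM
- compound 2, `CC[C@H](C)[C@H](N)CN(C(=O)[C@@H]1C[C@H]1c1ccccc1)c1ccc(-c2ccc(COC)cc2)cc1`, gives 35 nM

Compound 2 holds the lower of the two numbers in this assay; its separation from compound 1 is beyond the scatter, and compound 2 is the more potent of the pair on these two numbers alone. The two compounds differ in more than one place, so no single step can be read between them; the values simply show compound 2 well ahead.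

Compound 3, `CC[C@H](C)[C@H](N)CN(C(=O)[C@@H]1C[C@H]1c1ccccc1)c1ccc(-c2ccc(CNC)cc2)cc1`, is not yet measured in this assay. It is compound 2 with one change: methylamino in place of methoxy on a saturated chain carbon bound to an aromatic carbon. Going by the values given here, no measured pair carries this same change, so there is no step to lean on. The expectation for the step from compound 2 to compound 3 is that it stays within the scatter, or moves only slightly toward a higher number, with a 1.4-fold higher number from compound 2 to compound 3 (0.15 log units; within the scatter) as the expected size. Compound 3 is thus estimated at 50 nM in this assay, with a range from 15 nM to 200 nM.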

Compound 3, half-maximal effective concentration: 6400 nM
Beside the measured number, compound 3's estimate is 130-fold (2.11 log units) below it, outside the stated range (above it).
By their numbers in this assay, from the lowest: compound 2; then compounds 1 and 3 (each within the scatter of the next).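

In this assay, methylamino in place of methoxy on a saturated chain carbon bound to an aromatic carbon brings a 180-fold higher number from compound 2 to compound 3 (2.26 log units; beyond the scatter), so this position is far from indifferent to an exchange that leaves the count of 2 heavy atoms unchanged and swaps oxygen for nitrogen with 1 hydrogen-bond donor added. Compounds 1 and 2 differ in more than one place and could not tie any change in the number to a single site, whereas this pair ties a large step to this one place. No measurement at hand bears on the reason for the size of this step, and the pair alone does not separate the exchange of oxygen for nitrogen from the added hydrogen-bond donor.

Open, from the compounds shown here alone, is whether dimethylamino, which keeps the nitrogen without the hydrogen on it, or hydroxy, which keeps the oxygen and carries a hydrogen, would track compound 2 or compound 3 at this place. Also open, going by these compounds, are how a longer chain such as ethoxy would fare here and whether the same step would hold on the core of compound 1.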